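The source may report more compounds than this note shows. Statements on the series, on what has been measured and on what is new or still open speak of the compounds shown alone.

Compound 1 `CC(O)(CS(=O)(=O)c1ccccc1C(F)(F)F)C(=O)Nc1ccc(S(F)(F)(F)(F)F)cc1` gives 10800 nM in a functional assay on LNCaP cells (Homo sapiens) for antiproliferative activity, read by propidium iodide staining, with a stated time of 96 h; a higher number here means a weaker inhibitor, a lower number a stronger inhibitor. Compound 2 `CC(O)(CS(=O)(=O)c1ccc(OC(F)(F)F)cc1)C(=O)Nc1ccc(S(F)(F)(F)(F)F)cc1` differs from compound 1 by 4-(trifluoromethoxy)phenyl in place of 2-(trifluoromethyl)phenyl on a sulfonyl sulfur, and in this assay compound 2 gives 92800 nM, a step of an 8.6-fold higher number from compound 1 to compound 2 (0.93 log units; beyond the scatter). Compound 3 `CC(O)(CS(=O)(=O)c1ccccc1C(F)(F)F)C(=O)Nc1cccc(S(F)(F)(F)(F)F)c1` shares its atoms with compound 1 but joins them differently; the difference between the two cores is not broken down here. In this assay compound 3 gives 24900 nM. Compound 4 `CC(O)(CS(=O)(=O)c1ccc(OC(F)(F)F)cc1)C(=O)Nc1cccc(S(F)(F)(F)(F)F)c1` is not yet measured; it differs from compound 3 by 4-(trifluoromethoxy)phenyl in place of 2-(trifluoromethyl)phenyl on a sulfonyl sulfur, the same change made from compound 1 to compound 2 at the same place. For compound 4 a step of a 7.2-fold higher number from compound 3 to compound 4 (0.86 log units; beyond the scatter) is expected, resting on the measured step of an 8.6-fold higher number from compound 1 to compound 2 (0.93 log units; beyond the scatter). Compound 4 is therefore estimated at 180000 nM, with a range of 60000 nM to 500000 nM.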

Compound 4, half-maximal inhibitory concentration: 10700 nM
Compound 4: middle estimate off by 17-fold (1.23 log units), on the high side; the measured number lies below the stated range.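

In this assay, 4-(trifluoromethoxy)phenyl in place of 2-(trifluoromethyl)phenyl on a sulfonyl sulfur gives a 2.3-fold lower number from compound 3 to compound 4 (0.37 log units; beyond the scatter), so the change does not carry from one core to the other in either size or direction: the same change on two cores in this assay, an 8.6-fold higher number (0.93 log units; beyond the scatter) from compound 1 to compound 2 and a 2.3-fold lower number (0.37 log units; beyond the scatter) from compound 3 to compound 4, 20-fold (1.30 log units) apart, beyond the scatter of two such steps. Between these two cores, a step measured on the core of compound 1 is therefore no guide to the step on the core of compound 3. This rests on a single pair of steps and does not show which difference between the cores matters, or how the change would behave on a third core.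

Still open, going by these compounds, is how an unsubstituted phenyl, or a phenyl carrying an amine or a carboxylic acid, would behave on the sulfonyl sulfur of either core.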